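Swapping chloro for fluoro on the benzyl group

The source may report more compounds than this note shows. Statements on the series, on what has been measured and on what is new or still open speak of the compounds shown alone.

Measured compounds:
compound 1 `CC1=C(C(=O)Nc2ccc([N+](=O)[O-])cc2)C(c2ccc(Br)cc2)N=C(SCc2ccc(F)cc2)N1`: 27.2%
compound 2 `CC1=C(C(=O)Nc2ccc([N+](=O)[O-])cc2)C(c2cccc([N+](=O)[O-])c2)N=C(SCc2cccc(Cl)c2)N1`: 17.9%
compound 3 `CC1=C(C(=O)Nc2ccc([N+](=O)[O-])cc2)C(c2cccc([N+](=O)[O-])c2)N=C(SCc2ccc(Cl)cc2)N1`: 20%

In a functional assay on the whole organism (artery, strain albino) with Rattus norvegicus as the target, with a stated time of 240 min, at a dose of 10 mg/kg by the oral route (a lower number here means less inhibition, a higher number more inhibition at the dose given (going by the name of the read-out)), compound 3 gives 20%, a number that sits within the scatter of both compound 2 and compound 1, so the three measured compounds cannot be told apart. Compound 4 `CC1=C(C(=O)Nc2ccc([N+](=O)[O-])cc2)C(c2cccc([N+](=O)[O-])c2)N=C(SCc2ccc(F)cc2)N1` differs from compound 3 by fluoro in place of chloro on an aromatic carbon. For the measured compounds named here, the only single-point step seen so far, a number 2.1 percentage points higher from compound 2 to compound 3 (within the scatter), moved a chloro around the same ring and stayed within the scatter. Compound 1, which carries the fluoro but also a different group on the shared core, reads close to compound 3. No change beyond the scatter is therefore expected for compound 4 in this assay, so a number 1 percentage points higher from compound 3 to compound 4 (within the scatter) is the expected step. Compound 4 is estimated at 21%, between 10% and 32%.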

Compound 4, a percentage reported as inhibition, in the whole organism at one dose (the size of the read-out at that dose, not a potency): 22.6%
Compound 4: the middle estimate sits 1.6 percentage points below what was measured; the range from low to high includes it.
By their numbers in this assay, from the lowest: compounds 2, 3, 4 and 1 (each within the scatter of the next).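

In this assay, fluoro in place of chloro on this aromatic carbon gives a number 2.6 percentage points higher from compound 3 to compound 4 (within the scatter), so this halogen swap does not separate the two compounds. The other two changes behave alike: 4-fluorophenyl in place of 3-chlorophenyl gives a number 4.7 percentage points higher from compound 2 to compound 4 (within the scatter), and 3-nitrophenyl in place of 4-bromophenyl gives a number 4.6 percentage points lower from compound 1 to compound 4 (within the scatter). No measurement shown explains these steps. The compounds shown leave open whether a non-halogen group at this position, such as an amine or a methoxy group, would give a step beyond the scatter.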